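A few compounds are considered here, and "the series" means these few. Any claim that something is new, unique, unknown or untested is made for them only; others in the source may bear on it.

Values in an ADME assay on Vero cells (Chlorocebus sabaeus) for cytotoxicity, read by MTT assay, with a stated time of 72 h (on this read-out lower numbers stand for higher toxicity in this test and higher numbers for lower toxicity in this test), for the measured members of the series:

- compound 1, `COC(=O)c1cc(-c2cccc(NC(=O)c3ccc(OCc4ccc(Cl)cc4)cc3)c2)on1`: > 80 ug/mL, a limit of the assay rather than a number
- compound 2, `COC(=O)c1cc(-c2cccc(NC(=O)c3ccc(/C=C/C(=O)c4ccccc4)cc3)c2)on1`: > 50 ug/mL, also a limit of the assay
- compound 3, `COC(=O)c1cc(-c2cccc(NC(=O)c3ccc(/C=C/C(=O)c4ccc(F)cc4F)cc3)c2)on1`: > 40 ug/mL, again a limit of the assay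

Compound 3 therefore stands only at a limit in this assay, as do both other compounds (the limit of > 40 ug/mL in this assay, at which 1 of the 3 values shown sits, (the limit of > 50 ug/mL in this assay, at which 1 of the 3 values shown sits), (the limit of > 80 ug/mL in this assay, at which 1 of the 3 values shown sits)); none of the three reads as a number. The steps between them are accordingly unreadable: a step that the two limits leave unreadable from compound 1 to compound 2, a step that the two limits leave unreadable from compound 1 to compound 3 and a step that the two limits leave unreadable from compound 2 to compound 3 give no size and no direction.

Compound 4, `COC(=O)c1cc(-c2cccc(NC(=O)c3ccc(/C=C/C(=O)c4ccc(Cl)cc4Cl)cc3)c2)on1`, differs from compound 3 as follows: 2,4-dichlorophenyl in place of 2,4-difluorophenyl on a carbonyl carbon. The measured step that bears on this change is a step that the two limits leave unreadable from compound 2 to compound 3, which alters the same aryl group on the same carbonyl carbon, but it is not readable. Going by the values given here, no measured step in the set gives a size, so no step beyond the usual scatter is expected here.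

Compound 4 is estimated at 60 ug/mL in this assay, within 30 ug/mL to 120 ug/mL, most likely reported once more as a limit. The expected step is a step that the limit leaves unreadable from compound 3 to compound 4.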

Compound 4, half-maximal cytotoxic concentration: > 40 ug/mL
Compound 4: only a limit was reported; the forecaster's own chance of this, stated with the estimate: 70%; the middle value is on the limit's open side.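

In this assay compound 4 gives > 40 ug/mL, a limit of the assay and not a number. Going by these compounds alone, no step from compound 1, compound 2 or compound 3 to compound 4 can be read. The compounds shown leave open whether phenyl, 2,4-difluorophenyl and 2,4-dichlorophenyl on the carbonyl carbon differ at all in this read-out.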